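The source may hold more compounds than are shown below. What is called first, only, known or untested is meant among the compounds shown, and "the series" means these compounds.

Working notes on the series. For the measured compounds named here, in a toxicity assay on NIH3T3 cells (Mus musculus) for cytotoxicity, read by resazurin assay (on this read-out lower numbers stand for an effect already at smaller amounts and higher numbers for an effect only at larger amounts of compound), compound 1, `c1ccc(-c2ccc(Cn3cncc3CNc3cccc(-c4ccccc4)c3)cc2)cc1`, gives 10000 nM, the only true number available. Compound 2, `c1ccc(-c2ccc(Cn3cncc3CNc3ccc(-c4cncs4)c(-c4ccccc4)c3)cc2)cc1`, gives > 1000 nM, which is a limit. Compound 3, `c1ccc(-c2ccc(Cn3cncc3CNc3ccc(N4CCCC4)c(-c4ccccc4)c3)cc2)cc1`, gives > 1000 nM, which is also a limit. Where compound 1 stands relative to these two compounds therefore cannot be read, and the limit of > 1000 nM in this assay, at which 2 of the 3 values shown sit, is all that the pair provides.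

The next compound is compound 4, `Clc1ccc(Cn2cncc2CNc2cccc(-c3ccccc3)c2)cc1`. It differs from compound 1 as follows: chloro in place of phenyl on an aromatic carbon.

Two measured steps start from compound 1: a step that the limit leaves unreadable from compound 1 to compound 2 and a step that the limit leaves unreadable from compound 1 to compound 3. A third links the two products: a step that the two limits leave unreadable from compound 2 to compound 3. None of them has a readable size, and none replaces this phenyl, so they give no guide to the size or direction of the change. The expectation for this assay therefore rests on compound 1 at 10000 nM alone, with no shift beyond the scatter assumed. The expected result is no change at the digits printed from compound 1 to compound 4 (within the scatter). For compound 4 the estimated value is 10000 nM, with an expected range from 3000 nM to 30000 nM.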

Compound 4, half-maximal effective concentration: 10000 nM
The estimate for compound 4 equals the measured number at the digits printed, within the range that was stated.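

Chloro in place of phenyl, on an aromatic carbon para to a large group, gives no change at the digits printed from compound 1 to compound 4 (within the scatter) in this assay. For the compounds shown here, this is the first step with a readable size, and it shows that, in this one pair, a single chlorine atom can stand where a phenyl of 6 heavy atoms and one aromatic ring stood without moving the read-out beyond the scatter. The remaining steps cannot be read, and none of them replaces this phenyl, so they add nothing at this position: the limit of > 1000 nM in this assay, at which 2 of the 4 values shown sit.

Whether the read-out would also stay put with an amine, a carboxylic acid or a longer alkyl chain at this position remains open, since chloro and phenyl are the only two groups shown there. Also open, going by these compounds, is whether the same exchange would give the same result on the cores of compound 2 and compound 3, which carry a 1,3-thiazol-5-yl and a pyrrolidin-1-yl group.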